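The source may hold more compounds than are shown below. What is called first, only, known or untested is meant among the compounds shown, and "the series" means these compounds.

Measured so far: compound 1 `COc1cc(/C=N/Nc2nc(-c3ccc(C(F)(F)F)cc3)cs2)c(Br)c(Br)c1OC`, compound 2 `Fc1ccc(/C=N/Nc2nc(-c3cccc(Br)c3)cs2)cc1F` and compound 3 `Fc1ccc(/C=N/Nc2nc(-c3ccccc3)cs2)cc1F`.

In an ADME assay on HUVEC cells (Homo sapiens) for inhibition, read by MTT assay, with a stated time of 48 h (a lower number here means a stronger inhibitor, a higher number a weaker inhibitor), compound 1 gives > 100000 nM, which is a limit of the assay rather than a number. In this assay compound 2 gives > 100000 nM, again a limit. In this assay compound 3 likewise gives > 100000 nM, a limit.

The change from compound 2 to compound 3 is hydrogen in place of bromo on an aromatic carbon. The step it made, a step that the two limits leave unreadable from compound 2 to compound 3, cannot be sized, because of the limit of > 100000 nM in this assay, at which 3 of the 3 values shown sit.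

Compound 4 `COc1cc(/C=N/Nc2nc(-c3ccc(C(F)(F)F)cc3)cs2)cc(Br)c1OC` has not yet been measured. It differs from compound 1 by hydrogen in place of bromo on an aromatic carbon. This is the same kind of change as that from compound 2 to compound 3, but the surroundings differ: in compound 2 the bromo sits meta to a large group, whereas in compound 1 it sits ortho to a bromo group, ortho to a large group, meta to a methoxy group and para to a methoxy group. The difference between the two cores is not broken down here.

Compound 1 gives only a limit, > 100000 nM, so for compound 4 a step of a number no higher from compound 1 to compound 4 (the limit leaves the size open) is expected, resting on that limit alone. Compound 4 is therefore estimated at 100000 nM, most likely again as a limit.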

Compound 4, half-maximal inhibitory concentration: > 100000 nM
Compound 4 was reported as a limit; the forecaster's own chance of this, stated with the estimate: 85%; the middle value sits exactly at the limit.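

In this assay compound 4 gives > 100000 nM, again a limit and not a number. No size can be read for the step between compound 1 and compound 4, because both stop at the same limit: the limit of > 100000 nM in this assay, at which 4 of the 4 values shown sit. The compounds shown leave open how far each true value lies past that limit, and whether any change to these structures gives a measurable value in this assay.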